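Cyano in Place of Vinyl: Expected Hepatic Extraction

The source may report more compounds than this note shows. Statements on the series, on what has been measured and on what is new or still open speak of the compounds shown alone.

Measured compounds:
Compound 1, `CCC(CC)n1c(=O)[nH]c2nccnc21`: "not determined" (no result reported)
Compound 2, `C=Cc1cnc2[nH]c(=O)n(C(CC)CC)c2n1`: > 0.7

In an ADME assay on microsomes from liver (Rattus norvegicus), read by LC-MS, with a stated time of 90 min (on this read-out higher numbers stand for higher hepatic extraction and lower numbers for lower hepatic extraction), compound 1 has no result, being "not determined" (no result reported). For compound 2 this assay gives only a limit, > 0.7, which is the limit of > 0.7 in this assay, at which 1 of the 2 values shown sits. Within the data shown here, no step between two measured compounds can be drawn here, so compound 2 stands by itself at the upper edge of what this assay reports, and compound 1 adds no number to set beside it.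

Compound 3, `CCC(CC)n1c(=O)[nH]c2ncc(C#N)nc21`, differs from compound 2 by cyano in place of vinyl on an aromatic carbon. Among the measured compounds shown here, with no measured step to lean on, the step expected for compound 3 in this assay, a number at least 0.10 lower from compound 2 to compound 3 (that floor lies within the scatter), is a small move downward, and it may prove no larger than the scatter. In this assay compound 3 is expected to give 0.6, within a range of 0.4 to 0.85.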

Compound 3, hepatic extraction ratio: < 0.2
Compound 3: a limit, no number; the forecaster's own chance of this, stated with the estimate: 35%; middle value at least 0.40 from the limit.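

Cyano in place of vinyl on this aromatic carbon, next to the ring nitrogen, gives in this assay the first step that can be read: a number at least 0.50 lower from compound 2 to compound 3 (beyond the scatter). The position is thus one at which the read-out answers strongly to the group it carries, which compound 2 alone could not show. Both ends of the step are limits of the assay, so the step is a floor and not a measured size: the limit of < 0.2 in this assay, at which 1 of the 3 values shown sits.

From the compounds shown here alone, compound 1, with hydrogen on this carbon, gives "not determined" (no result reported), so it stays open whether the drop follows from cyano entering or from vinyl leaving. Also open, going by these compounds, is where a carboxamide, a methoxy group or a chlorine atom on the same carbon would fall in this assay.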